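Methoxycarbonyl to (2-Hydroxyethyl)carbamoyl: An Expected Step

The source may hold more compounds than are shown below. What is called first, only, known or untested is meant among the compounds shown, and "the series" means these compounds.

Three compounds have been measured in an ADME assay on BHK15 cells (Mesocricetus auratus) for inhibition, read by XTT assay, with a stated time of 36 h; a lower number here means a stronger inhibitor of growth, a higher number a weaker inhibitor of growth:

compound 1 `COC(=O)c1sc(-c2ccc(Cl)cc2)nc1C(Br)Br`: 222000 nM
compound 2 `CCN(CC)C(=O)c1sc(-c2ccc(Cl)cc2)nc1C(Br)Br`: 63500 nM
compound 3 `CC(=O)c1sc(-c2ccc(Cl)cc2)nc1C(Br)Br`: 83500 nM

Compound 1 stands highest of the three numbers. Its nearest neighbour is compound 3, reached by a 2.7-fold lower number from compound 1 to compound 3 (0.42 log units; beyond the scatter), and its furthest is compound 2, reached by a 3.5-fold lower number from compound 1 to compound 2 (0.54 log units; beyond the scatter). Compound 2 and compound 3 lie within the scatter of each other, as a 1.3-fold higher number from compound 2 to compound 3 (0.12 log units; within the scatter) shows.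

The unmeasured compound 4 `O=C(NCCO)c1sc(-c2ccc(Cl)cc2)nc1C(Br)Br` differs from compound 1 in one place: (2-hydroxyethyl)amino in place of methoxy on a carbonyl carbon. The two steps that bear on this change are the ones that also replace methoxy on the carbonyl carbon, namely a 3.5-fold lower number from compound 1 to compound 2 (0.54 log units; beyond the scatter) and a 2.7-fold lower number from compound 1 to compound 3 (0.42 log units; beyond the scatter); both were modest lowerings. Because a 3.5-fold lower number from compound 1 to compound 2 (0.54 log units; beyond the scatter) and a 2.7-fold lower number from compound 1 to compound 3 (0.42 log units; beyond the scatter) were both modest lowerings from replacing methoxy at that carbonyl carbon, a modest lowering is expected again, in this assay amounting to a 2.8-fold lower number from compound 1 to compound 4 (0.44 log units; beyond the scatter). Compound 4 is therefore estimated to give 80000 nM, within a range from 30000 nM to 200000 nM.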

Compound 4, concentration for 50% growth inhibition: 40800 nM
Beside the measured number, compound 4's estimate is 2.0-fold (0.29 log units) above it; the measured number falls inside the stated range.
By their numbers in this assay, from the lowest: compounds 4, 2 and 3 (each within the scatter of the next, the first and the last beyond it); then compound 1.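

In this assay a third replacement of methoxy on the carbonyl carbon again lowers the number, with a 5.4-fold lower number from compound 1 to compound 4 (0.74 log units; beyond the scatter) in this case, so all three groups tried there so far give a lower number than methoxy. The new group also separates from methyl on that carbon, with a 2.0-fold lower number from compound 3 to compound 4 (0.31 log units; beyond the scatter) beyond the scatter. It does not separate from diethylamino, however, as a 1.6-fold lower number from compound 2 to compound 4 (0.19 log units; within the scatter) stays within the scatter, so two differently built amino groups on the carbonyl carbon cannot be told apart here.

From the compounds shown here alone, it remains open how a plain ethylamino group, a longer hydroxyalkyl chain or a carboxylic acid on this carbonyl carbon would read, and so whether the hydroxyl of the new group counts at all. No measurement offered here accounts for these steps.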